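The source may report more compounds than this note shows. Statements on the series, on what has been measured and on what is new or still open speak of the compounds shown alone.

Compound 1 `COc1ccc2c(=O)c(/C=C/C(=O)Nc3cccc(C)c3)coc2c1` and compound 2 `COc1ccc2c(=O)c(/C=C/C(=O)Nc3cc(C)ccc3C)coc2c1` share one core. In a functional assay on L02 cells (Homo sapiens) for inhibition, read by MTT assay, with a stated time of 48 h (a higher number here means a weaker inhibitor, a lower number a stronger inhibitor), compound 1 gives only a limit, > 200000 nM. In this assay compound 2 likewise gives only a limit, > 200000 nM. The step that the two limits leave unreadable from compound 1 to compound 2 is unreadable since both values sit at the limit of > 200000 nM in this assay, at which 2 of the 2 values shown sit. Compound 2 therefore stands at the limit, without a number. Compound 3 `COc1cccc(NC(=O)/C=C/c2coc3cc(OC)ccc3c2=O)c1` differs from compound 2 by 3-methoxyphenyl in place of 2,5-dimethylphenyl on an amide-type nitrogen. For the measured compounds named here, the only measured step, a step that the two limits leave unreadable from compound 1 to compound 2, concerns methyl in place of hydrogen on an aromatic carbon, not the amide-type nitrogen, and gives no readable size. Compound 3 is expected to remain at the limit, a step that the limit leaves unreadable from compound 2 to compound 3, with an estimate of 300000 nM (range 100000 nM to 1000000 nM).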

Compound 3, half-maximal inhibitory concentration: > 200000 nM
Compound 3: no number, only a limit (the forecaster's own chance of this, stated with the estimate: 85%); the middle value lies beyond the limit too.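

For the compounds shown here, no step among compound 1, compound 2 and compound 3 can be read in this assay, since each gives only a limit: the limit of > 200000 nM in this assay, at which 3 of the 3 values shown sit. The compounds shown leave open how large any of these substituent effects would be in a numerical reading.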